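Aryl swap on the sulfur of compound 2

A few compounds are considered here, and "the series" means these few. Any claim that something is new, unique, unknown or untested is made for them only; others in the source may bear on it.

compound 1 `Nc1cc(N)c2nc(-c3ccccc3)c(Oc3ccc(Cl)c(Cl)c3)nc2c1` – < 100000 nM
compound 2 `Nc1cc(N)c2nc(-c3ccccc3)c(Sc3ccc(Cl)c(Cl)c3)nc2c1` – 30900 nM
compound 3 `Nc1cc(N)c2nc(-c3ccccc3)c(Sc3ccc(F)cc3)nc2c1` – not yet measured

Of the compounds shown here, two have been tested in a functional assay on A498 cells (Homo sapiens) for inhibition, read by sulforhodamine B assay, with a stated time of 48 h; on this read-out higher numbers stand for weaker inhibition of growth and lower numbers for stronger inhibition of growth. For compound 1 the reading is a limit of the assay, < 100000 nM (the limit of < 100000 nM in this assay, at which 1 of the 2 values shown sits). Among the compounds with values here, compound 2 gives 30900 nM in this assay, the only number so far, and it therefore stands alone without a measured neighbour to rank against. The step that the limit leaves unreadable from compound 1 to compound 2 cannot be sized. That step exchanges the linking atom between the two rings, not the distal ring itself.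

Compound 3 differs from compound 2 in one place: 4-fluorophenyl in place of 3,4-dichlorophenyl on a sulfur. Within the data shown here, no measured step touches this ring, and the single step that has been recorded is unreadable in any case, so the measured data give no direction for this change. The step from compound 2 to compound 3 is expected to be a 1.3-fold higher number from compound 2 to compound 3 (0.11 log units; within the scatter), nothing beyond the scatter. In this assay compound 3 is accordingly estimated at 40000 nM, with a range from 12000 nM to 100000 nM, held wide.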

Compound 3, concentration for total growth inhibition: < 100000 nM
Compound 3 gave a limit, no number; the forecaster's own chance of this, stated with the estimate: 35%; the middle value does not contradict the limit.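

In this assay compound 3 gives < 100000 nM, a limit and not a number, so neither the step to compound 3 from compound 2 nor the one from compound 1 can be read: the limit of < 100000 nM in this assay, at which 2 of the 3 values shown sit.

The compounds shown leave open how 4-fluorophenyl and 3,4-dichlorophenyl on a sulfur compare in this assay, and how (3,4-dichlorophenyl)sulfanyl compares with 3,4-dichlorophenoxy.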